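The source may report more compounds than this note shows. Statements on the series, on what has been measured and on what is new or still open speak of the compounds shown alone.

Compound 1 `CCc1nc(N)nc2c1c(-c1ccc3oc(N)nc3c1)nn2C(C)C`, compound 2 `CC(C)n1nc(-c2ccc3oc(N)nc3c2)c2c(CO)nc(N)nc21` and compound 3 `CC(C)n1nc(-c2ccc3oc(N)nc3c2)c2c(Br)nc(N)nc21` share one core and differ only at a single aromatic carbon. In an ADME assay on cells (Hepatocyte, Homo sapiens) for metabolic stability, read by LC-MS, with a stated time of 90 min, tested at 1 uM (a higher number here means faster removal of the compound, a lower number slower removal), compound 2 gives < 5 uL/min, a limit of the assay rather than a number. Compound 1 gives < 5 uL/min, also a limit. Compound 3 gives 55 uL/min. Within the data shown here, the step of an at least 11-fold higher number from compound 2 to compound 3 (1.04 log units; beyond the scatter) is the one clear change among the three, while the step that the two limits leave unreadable from compound 1 to compound 2 cannot be sized, as the limit of < 5 uL/min in this assay, at which 2 of the 3 values shown sit, shows. Compound 4 `CC(C)n1nc(-c2ccc3oc(N)nc3c2)c2c(C#N)nc(N)nc21` differs from compound 2 by cyano in place of hydroxymethyl on an aromatic carbon. Only the bromo step offers guidance, and a cyano is not a bromo, so a small rise is expected, an at least 1.6-fold higher number from compound 2 to compound 4 (0.20 log units; that floor lies within the scatter). Compound 4 is therefore estimated at 8 uL/min, between 3 uL/min and 25 uL/min.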

Compound 4, intrinsic clearance in a liver preparation (reported as CLH), per the amount of preparation that the assay uses: < 5 uL/min
Compound 4 gave a limit, no number; the forecaster's own chance of this, stated with the estimate: 40%; at least 1.6-fold (0.20 log units) between middle value and limit.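

Cyano in place of bromo gives an at least 11-fold lower number from compound 3 to compound 4 (1.04 log units; beyond the scatter) in this assay, so among the four groups shown on this aromatic carbon, only bromo goes with a high number. Nitrile and hydroxymethyl share the same limit, as does ethyl, so the steps among compound 1, compound 2 and compound 4 cannot be read: the limit of < 5 uL/min in this assay, at which 3 of the 4 values shown sit.

On these data alone, how these three groups rank beneath that limit stays open. Also open, as far as these compounds go, is whether chloro or an amine on this aromatic carbon would follow bromo or cyano.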